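From methoxy to 1H-pyrrol-1-yl at the assay limit

The source may hold more compounds than are shown below. What is called first, only, known or untested is meant among the compounds shown, and "the series" means these compounds.

Measured in an ADME assay on HeLa cells (Homo sapiens) for cytotoxicity, read by crystal violet staining, with a stated time of 72 h; a lower number here means that less compound is tolerated, a higher number that more compound is tolerated:
compound 1 `CCOC(=O)c1cc(CCCOc2ccc(-c3noc(C(F)(F)F)n3)cc2OC)on1`: > 100000 nM (a limit)
compound 2 `CCOC(=O)c1cc(CCCOc2c(OC)cc(-c3noc(C(F)(F)F)n3)cc2[N+](=O)[O-])on1`: > 100000 nM (a limit)
compound 3 `COc1cc(-c2noc(C(F)(F)F)n2)ccc1OCCCc1cc(C(=O)N(C)C)no1`: 68000 nM

Compound 1 stands at > 100000 nM, which is a limit and not a number. This is the limit of > 100000 nM in this assay, at which 2 of the 3 values shown sit.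

Compound 4 `CCOC(=O)c1cc(CCCOc2ccc(-c3noc(C(F)(F)F)n3)cc2-n2cccc2)on1` keeps the core of compound 1 and changes one group: 1H-pyrrol-1-yl in place of methoxy on an aromatic carbon. In short, 1H-pyrrol-1-yl takes the place of methoxy on an aromatic carbon.

The measured steps are a step that the two limits leave unreadable from compound 1 to compound 2 and an at least 1.4-fold lower number from compound 1 to compound 3 (0.16 log units; that floor lies within the scatter). Neither of them alters the methoxy group, so they offer only weak guidance. The first has no readable size, and the second does not clearly exceed the usual scatter. No clear step beyond the scatter is therefore expected in this assay, although a small move towards a lower number is possible, and another limit could appear. The expected change is an at least 1.4-fold lower number from compound 1 to compound 4 (0.15 log units; that floor lies within the scatter). For compound 4 the estimated value is 70000 nM, with an expected range from 25000 nM to 150000 nM.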

Compound 4, half-maximal cytotoxic concentration: 57300 nM
Beside the measured number, compound 4's estimate is 1.2-fold (0.09 log units) above it; low and high end bracket the measured number.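

In this assay, the change on this aromatic carbon gives an at least 1.7-fold lower number from compound 1 to compound 4 (0.24 log units; that floor lies within the scatter). Unlike the earlier steps, this one alters the methoxy group itself, and it shows that 1H-pyrrol-1-yl, with its five-membered aromatic ring, can take that place and give a measured number rather than a limit. Compound 1 holds only a limit, so the real step could be larger than its printed floor, and that floor alone does not show a change beyond the usual scatter: the limit of > 100000 nM in this assay, at which 2 of the 4 values shown sit.

The compounds shown leave open whether another group on this carbon, such as an amine or a chlorine atom, would give a step clearly beyond the scatter. They also leave open how 1H-pyrrol-1-yl would behave with dimethylamino in place of ethoxy on the carbonyl carbon.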